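A few compounds are considered here, and "the series" means these few. Any claim that something is new, unique, unknown or untested is made for them only; others in the source may bear on it.

Measured so far in an ADME assay on HepG2 2.2.15 cells (Homo sapiens) for cytotoxicity, read by MTT assay, with stated times of 48 h and 9 days; a higher number here means that more compound is tolerated, a lower number that less compound is tolerated:
compound 1, `COc1ccc2c(=O)c(/C=C/C(=O)NCc3ccccc3)coc2c1`, gives 376000 nM;
compound 2, `CCOc1ccc(NC(=O)/C=C/c2coc3cc(OC)ccc3c2=O)cc1`, gives 460000 nM;
compound 3, `COc1ccc2c(=O)c(/C=C/C(=O)NCc3ccc(C)cc3)coc2c1`, gives 257000 nM.

Compound 3 has the lowest of the three numbers, but all three sit within the scatter of one another: a 1.5-fold lower number from compound 1 to compound 3 (0.17 log units; within the scatter) and a 1.8-fold lower number from compound 2 to compound 3 (0.25 log units; within the scatter), so none of the three can be called better or worse tolerated than the others.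

Compound 4, `COc1ccc2c(=O)c(/C=C/C(=O)Nc3ccccc3C)coc2c1`, is reached from compound 3 by one change: 2-methylphenyl in place of 4-methylbenzyl on an amide-type nitrogen. The shared core and the amide are kept.

For the measured compounds named here, two measured steps bear on this kind of change, in which the group on the amide-type nitrogen is swapped between a benzyl-type group and a phenyl-type group: a 1.2-fold higher number from compound 1 to compound 2 (0.09 log units; within the scatter) and a 1.8-fold lower number from compound 2 to compound 3 (0.25 log units; within the scatter). Moving a methyl onto the ring, a 1.5-fold lower number from compound 1 to compound 3 (0.17 log units; within the scatter), also stayed within the scatter. Nothing in these three steps points to a shift beyond the scatter in this assay in either direction, so no real step is expected.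

Compound 4 is therefore expected to give about 300000 nM in this assay, with a range from 150000 nM to 600000 nM. The expected step, a 1.2-fold higher number from compound 3 to compound 4 (0.07 log units; within the scatter), is estimated to stay within the scatter.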

Compound 4, half-maximal cytotoxic concentration: 59700 nM
The estimate for compound 4 lay 5.0-fold (0.70 log units) above the measured number, and the stated range ends above it.
By their numbers in this assay, from the lowest: compound 4; then compounds 3, 1 and 2 (each within the scatter of the next).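

In this assay, for the compounds shown here, the group on the amide-type nitrogen turns out to matter: 2-methylphenyl in place of 4-methylbenzyl gives a 4.3-fold lower number from compound 3 to compound 4 (0.63 log units; beyond the scatter), the first step to pass beyond the scatter. The same group also sets compound 4 apart from the other two, with a 7.7-fold lower number from compound 2 to compound 4 (0.89 log units; beyond the scatter) and a 6.3-fold lower number from compound 1 to compound 4 (0.80 log units; beyond the scatter), which makes compound 4 the least tolerated of the four, while benzyl, 4-methylbenzyl and 4-ethoxyphenyl at this place could not be told apart. Nothing shown here offers a measured reason for this drop.

As far as these compounds go, two things change at once in this step, since a benzyl-type group gives way to a phenyl-type group and the methyl also sits at a different ring position, so it stays open whether either change alone accounts for the lower number. From the compounds shown here alone, a plain phenyl or a 4-methylphenyl on the amide-type nitrogen would separate the two, and how a ring carrying an amine or a carboxylic acid would behave at this place also remains unknown.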